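The source may hold more compounds than are shown below. What is called first, only, known or untested is meant among the compounds shown, and "the series" means these compounds.

Compound 1 `COc1ccc(-c2coc(=O)n2-c2cc(OC)c(OC)c(OC)c2)cc1` is measured in a functional assay on B16 cells (Mus musculus) for inhibition (on this read-out lower numbers stand for stronger inhibition and higher numbers for weaker inhibition), where compound 1 gives 7.9 nM. Compound 2 `COc1ccc(-c2coc(=O)n2-c2cc(OC)c(OC)c(OC)c2)cc1O` gives 0.9 nM in this assay; the change between them is hydroxy in place of hydrogen on an aromatic carbon, and the step it made is an 8.8-fold lower number from compound 1 to compound 2 (0.94 log units; beyond the scatter). Compound 3 `COc1ccc(-c2oc(O)nc2-c2cc(OC)c(OC)c(OC)c2)cc1` has the same atoms as compound 1 joined differently; the difference between the two cores is not broken down here. In this assay compound 3 gives 14.5 nM, which lies within the scatter of compound 1 and beyond it from compound 2. Compound 4 `COc1ccc(-c2oc(O)nc2-c2cc(OC)c(OC)c(OC)c2)cc1O` differs from compound 3 by hydroxy in place of hydrogen on an aromatic carbon, the same change already seen from compound 1 to compound 2. Among the measured compounds shown here, the step is expected to be a 7.3-fold lower number from compound 3 to compound 4 (0.86 log units; beyond the scatter), resting on the single earlier step of an 8.8-fold lower number from compound 1 to compound 2 (0.94 log units; beyond the scatter) made on the core of compound 1. Compound 4 is thus expected to give about 2 nM, between 0.7 nM and 6 nM.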

Compound 4, half-maximal inhibitory concentration: 5.4 nM
For compound 4 the middle estimate is 2.7-fold (0.43 log units) below the measured one, within the range that was stated.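

In this assay, hydroxy in place of hydrogen on the aromatic carbon again gives a lower number, a 2.7-fold lower number from compound 3 to compound 4 (0.43 log units; beyond the scatter), so the direction of the change carries over from the core of compound 1 to the core of compound 3. Its size does not carry over, as the two steps differ: the same change on two cores in this assay, an 8.8-fold lower number (0.94 log units; beyond the scatter) from compound 1 to compound 2 and a 2.7-fold lower number (0.43 log units; beyond the scatter) from compound 3 to compound 4, 3.3-fold (0.51 log units) apart, beyond the scatter of two such steps This shows only that, across these two cores, the gain from the change depends on the core; two pairs give no rule for other cores and do not show what sets the difference.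

The compounds shown leave open how an amine or a longer alkoxy chain in the place of the hydroxy would behave on either core. They also leave open whether the change keeps its direction on any further core.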